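Splitting compound 3 into a single defined stereoisomer

A few compounds are considered here, and "the series" means these few. Any claim that something is new, unique, unknown or untested is made for them only; others in the source may bear on it.

The shared core carries an isopropyl group and a methylcyclohexyl ether, and compound 3 `CC(C)c1c(OC2CCCCC2C)cc(CCc2ccccc2)[nH]c1=O` joins a phenethyl group to that core with both ring stereocentres drawn without a configuration. In an ADME assay on TZM cells (Homo sapiens) for cytotoxicity (a higher number here means that more compound is tolerated, a lower number that less compound is tolerated), compound 3 gives 114000 nM. Compound 1 `CC(C)c1c(OC2CCCCC2C)cc(Cc2ccc(Cl)cc2)[nH]c1=O` gives 109000 nM in this assay, and the step of a 1.0-fold higher number from compound 1 to compound 3 (0.02 log units; within the scatter) shows the two are within the scatter of each other. Compound 2 `CC(C)c1c(O[C@H]2CCCC[C@@H]2C)cc(CCc2ccccc2)[nH]c1=O` has both stereocentres drawn as S, and in this assay compound 2 reaches only the limit of > 300000 nM, which is a limit of the assay and not a number. The step of an at least 2.6-fold lower number from compound 2 to compound 3 (0.42 log units; beyond the scatter) is therefore at least modest, and it rests on the limit of > 300000 nM in this assay, at which 1 of the 3 values shown sits, and on (the fact that one of compounds 2 and 3 is drawn with a defined configuration and the other without, at the place where they differ).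

Compound 4 `CC(C)c1c(O[C@H]2CCCC[C@H]2C)cc(CCc2ccccc2)[nH]c1=O` differs from compound 3 in the same way: the two compounds have the same atoms and bonds; at least one stereo element is drawn with a configuration in one of them and without one in the other: 2 of 2 stereo elements differ; a stereocentre at a saturated ring carbon is drawn without a configuration in compound 3 and S in compound 4; a stereocentre at a saturated ring carbon is drawn without a configuration in compound 3 and R in compound 4. Because an at least 2.6-fold lower number from compound 2 to compound 3 (0.42 log units; beyond the scatter) shows compound 2 tolerated more than compound 3, the other defined isomer is expected to sit at or somewhat below compound 3. For compound 4 the step of a 1.6-fold lower number from compound 3 to compound 4 (0.21 log units; within the scatter) is estimated as a modest lowering. Compound 4 is therefore expected to give 70000 nM, between 30000 nM and 200000 nM.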

Compound 4, half-maximal cytotoxic concentration: 189000 nM
Compound 4: the middle estimate sits 2.7-fold (0.43 log units) below what was measured; low and high end bracket the measured number.
By their numbers in this assay, from the lowest: compounds 1, 3 and 4 (each within the scatter of the next). At a limit, above all of these: compound 2.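

The change to a defined configuration gives a 1.7-fold higher number from compound 3 to compound 4 (0.22 log units; within the scatter) in this assay, so here, unlike with compound 2, fixing both ring stereocentres does not clearly shift the number from that of the undefined form: the fact that one of compounds 3 and 4 is drawn with a defined configuration and the other without, at the place where they differ. Compound 2 gives > 300000 nM, which is a limit of the assay and not a number. Among the compounds shown here, changing only one ring stereocentre, from S in compound 2 to R in compound 4, gives an at least 1.5-fold lower number from compound 2 to compound 4 (0.20 log units; that floor lies within the scatter), so this direct comparison of two defined stereoisomers cannot yet separate them, even though they are the closest pair in the set: the fact that compounds 2 and 4 differ only in the configuration as drawn.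

Going by these compounds, how far the true value of compound 2 lies beyond its limit stays open, and with it the real size of the gap between these two stereoisomers. Also open, on these data alone, are how the remaining stereoisomers of the methylcyclohexyl ether behave, and whether the same picture holds with a longer chain in place of the phenethyl group or with an amine on its phenyl ring.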